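Swapping phenyl for acetyl on a ring nitrogen

The source may report more compounds than this note shows. Statements on the series, on what has been measured and on what is new or still open speak of the compounds shown alone.

Compound 1 `CC1=NN(c2ccccc2)C(=O)/C1=N/Nc1cccc(-c2nc3ccccc3s2)c1`: 12300 nM
Compound 2 `O=C(Nc1cccc(-c2nc3ccccc3s2)c1)c1cccnc1`: 15000 nM

Both compounds were tested in a functional assay on MCF7 cells (Homo sapiens) for inhibition; a higher number here means a weaker inhibitor, a lower number a stronger inhibitor. Compound 1 gives 12300 nM and compound 2 gives 15000 nM. These two values lie within the usual scatter of each other, so compound 1 stands level with compound 2 and neither can be ranked above the other.

The next compound, compound 3 `CC(=O)N1N=C(C)/C(=N\Nc2cccc(-c3nc4ccccc4s3)c2)C1=O`, keeps most of compound 1 but carries acetyl in place of phenyl on an amide-type nitrogen in a ring. Among the compounds with values here, no two measured compounds differ in one place only, so the data do not show directly what a single change does in this assay. Compound 2 has a quite different group on the shared core and still gives 15000 nM, so a step beyond the scatter, in either direction, is not expected here. The expected change is a 1.1-fold higher number from compound 1 to compound 3 (0.06 log units; within the scatter). For compound 3 the estimate is 14000 nM, with an expected range from 4500 nM to 40000 nM.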

Compound 3, half-maximal inhibitory concentration: 12300 nM
Estimate against measurement, compound 3: 1.1-fold (0.06 log units) above; measured number inside the range.
By their numbers in this assay, from the lowest: compounds 1, 3 and 2 (each within the scatter of the next).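

Within the data shown here, this is the first pair of compounds that differ in one place only, so the effect of a single change can now be read directly. In this assay, replacing phenyl with acetyl on the amide-type nitrogen in the ring gives no change at the digits printed from compound 1 to compound 3 (within the scatter), even though the change removes a six-membered aromatic ring of carbon only and introduces a group with no ring and a hydrogen-bond acceptor. For this pair, the aromatic ring at this position is therefore not required to keep the number at this level, but nothing measured here explains why the two compounds match.

One swap cannot show whether this nitrogen tolerates every kind of group, or whether the number simply failed to respond to these two. A chain ending in an amine or a carboxylic acid on this nitrogen, or an ethyl group in place of the methyl group on the ring, could show whether the number can move beyond the scatter through changes to this ring.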